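Replacing the methylsulfonyl group on the ring nitrogen with a furanylmethyl

The compounds below may be only part of what the source reports. "The series", "measured", "known", "first", "only" and "open" are said of these compounds alone.

This account follows a single change made to a shared core. Of the compounds shown here, three have been measured in an assay on HEK293 cells for agonist activity at Toll-like receptor 8 (Homo sapiens), read by a luciferase reporter, with a stated time of 6 h; a lower number here means that less compound is needed, a higher number that more compound is needed for the effect. Compound 1 `CCCCNc1nc(N)nc2c1CCN(Cc1ccccc1)C2` gives 0.4 uM in this assay. Compound 3 `CCCCNc1nc(N)nc2c1CN(Cc1ccc(C(C)(C)C)cc1)CC2` gives 0.66 uM. Compound 2 `CCCCNc1nc(N)nc2c1CN(S(C)(=O)=O)CC2` gives 9.9 uM, the highest of the three numbers, and both other values lie beyond the usual scatter from it, so compound 2 needs clearly more material than compound 1 or compound 3 to produce the effect.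

Compound 4 `CCCCNc1nc(N)nc2c1CN(Cc1ccco1)CC2` has not yet been measured. It differs from compound 2 in one place: (furan-2-yl)methyl in place of methylsulfonyl on an amine nitrogen in a ring. For the measured compounds named here, no measured pair in this set shows exactly this exchange, so the size of the step can only be judged from the values shown. Compound 1 and compound 3 both carry a group with an aromatic ring attached through a single carbon on the ring nitrogen and both sit well below compound 2; the furanylmethyl of compound 4 is of that same kind in the counted sense, so a move downward, beyond the scatter, is expected. Compound 4 is estimated at 0.8 uM, within a range of 0.3 uM to 2.5 uM. This amounts to an expected step of a 12-fold lower number from compound 2 to compound 4 (1.09 log units; beyond the scatter). That expectation rests on the value of compound 1, 0.4 uM, and on the value of compound 3, 0.66 uM.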

Compound 4, minimum effective concentration: 0.08 uM
Compound 4: middle estimate off by 10-fold (1.00 log units), on the high side, outside the stated range (below it).
By their numbers in this assay, from the lowest: compound 4; then compounds 1 and 3 (each within the scatter of the next); then compound 2.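

The exchange of methylsulfonyl for (furan-2-yl)methyl on an amine nitrogen in a ring gives a 120-fold lower number from compound 2 to compound 4 (2.09 log units; beyond the scatter) in this assay, a large step and the first that can be read directly at this position. For the compounds shown here, it shows that the group on this nitrogen can move the number over a wide span within the shared core, and that the lower end of that span extends past the values of the earlier compounds. Compound 3 gives 0.66 uM while compound 4 gives 0.08 uM, so these two groups, each holding an aromatic ring attached through a single carbon, are not interchangeable here. The data offer no measured explanation for the size of this step.

The compounds shown leave open whether an unsubstituted benzyl, a thiophen-2-ylmethyl or a pyridin-2-ylmethyl on this same nitrogen would give a number close to that of compound 4. They also leave open whether the aromatic ring itself matters, a question that a tetrahydrofuran-2-ylmethyl at this place could address.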